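Trimming the side chain of compound 3 to a bare piperidine

This account rests on a few compounds, and the source may have more. Where it says the series, first, only, none or still open, it means among the compounds named here.

Among the three measured compounds, compound 3 `OC1(COc2ccc([C@H]3CC[C@]4(CC3)OOC3(O4)C4CC5CC(C4)CC3C5)cc2)CCNCC1` is the only one with an actual number: in an ADME assay on microsomes from liver (Homo sapiens) for metabolic stability, read by LC-MS, tested at 1 uM (on this read-out higher numbers stand for fast clearance and lower numbers for slow clearance), compound 3 gives 16 mL.min-1.g-1. Compound 1 `N[C@H]1CC[C@@H](Oc2ccc([C@H]3CC[C@]4(CC3)OOC3(O4)C4CC5CC(C4)CC3C5)cc2)CC1` reaches only the limit of this assay, giving < 7 mL.min-1.g-1. Compound 2 `NCCCCCOc1ccc([C@H]2CC[C@]3(CC2)OOC2(O3)C3CC4CC(C3)CC2C4)cc1` likewise sits at that limit, with < 7 mL.min-1.g-1. Both of these rest at the limit of < 7 mL.min-1.g-1 in this assay, at which 2 of the 3 values shown sit, so the step that the two limits leave unreadable from compound 1 to compound 2 cannot be read.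

Compound 4 `c1cc([C@H]2CC[C@]3(CC2)OOC2(O3)C3CC4CC(C3)CC2C4)ccc1OC1CCNCC1` differs from compound 3 by piperidin-4-yl in place of (4-hydroxypiperidin-4-yl)methyl on an oxygen on an aromatic ring. The same oxygen on the aromatic ring carried a 4-aminocyclohexyl in compound 1 and a 5-aminopentyl in compound 2, and in compound 4 it carries piperidin-4-yl, a ring that joins through a ring carbon as the 4-aminocyclohexyl did.

The measured steps that bear on this are an at least 2.2-fold higher number from compound 1 to compound 3 (0.35 log units; beyond the scatter) and an at least 2.2-fold higher number from compound 2 to compound 3 (0.35 log units; beyond the scatter): replacing either of those chains with the (4-hydroxypiperidin-4-yl)methyl raised the number beyond the scatter. Going the other way, from the (4-hydroxypiperidin-4-yl)methyl back to a simple ring on the oxygen, the expected step is a 2.0-fold lower number from compound 3 to compound 4 (0.30 log units; within the scatter), towards slower clearance. For compound 4 the estimated clearance in this assay is 8 mL.min-1.g-1, within a range from 4 mL.min-1.g-1 to 16 mL.min-1.g-1, with a fair chance that it again comes out only as a limit.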

Compound 4, intrinsic clearance in microsomes: 15 mL.min-1.g-1
Compound 4: middle estimate off by 1.9-fold (0.27 log units), on the low side; the range from low to high includes it.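

In this assay, the exchange of (4-hydroxypiperidin-4-yl)methyl for piperidin-4-yl on this oxygen gives a 1.1-fold lower number from compound 3 to compound 4 (0.03 log units; within the scatter), so the side chain can lose its hydroxyl and its linking carbon with no readable difference in clearance. Both side chains holding a piperidine ring now stand apart from the two earlier amines, with an at least 2.1-fold higher number from compound 1 to compound 4 (0.33 log units; beyond the scatter) and an at least 2.1-fold higher number from compound 2 to compound 4 (0.33 log units; beyond the scatter), which suggests, across these four compounds only, that the higher clearance goes with the piperidine ring rather than with the hydroxyl. The true size of those two steps stays open-ended, because each starts from a compound that gives only a limit and not a number: the limit of < 7 mL.min-1.g-1 in this assay, at which 2 of the 4 values shown sit.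

The compounds shown leave open what the hydroxyl and the linking carbon each do alone, and a (piperidin-4-yl)methyl on the same oxygen would separate the two. On these data alone, it is also open whether the ring nitrogen matters, which a piperidine with a methyl on its nitrogen, or a tetrahydropyran-4-yl ring with an oxygen in place of that nitrogen, could test.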